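The source may hold more compounds than are shown below. What is called first, only, known or untested is meant among the compounds shown, and "the series" means these compounds.

Of the compounds shown here, three sharing one core have been measured in an assay on HEK293 cells for inhibition of Fatty-acid amide hydrolase 1 (Homo sapiens), read by fluorescence; a higher number here means a weaker inhibitor, a lower number a stronger inhibitor. Compound 1 `Cn1ccc2cc(-c3ccc4oc(Cc5ccccc5)nc4c3)ccc21` gives 488 nM, compound 2 `Cn1ccc2cc(-c3ccc4oc(Nc5ccc(F)cc5)nc4c3)ccc21` gives 99 nM, and compound 3 `COc1ccc(Nc2nc3cc(-c4ccc5c(ccn5C)c4)ccc3o2)cc1` gives 280 nM. Compound 3 thus stands second highest of the three. The step of a 2.8-fold higher number from compound 2 to compound 3 (0.45 log units; beyond the scatter) lies beyond the scatter, while a 1.7-fold lower number from compound 1 to compound 3 (0.24 log units; within the scatter) stays within it. Compound 4 `Cn1ccc2cc(-c3ccc4oc(N5CCCC5)nc4c3)ccc21` carries pyrrolidin-1-yl in place of (4-methoxyphenyl)amino on an aromatic carbon. Among the measured compounds shown here, no measured step swaps an arylamino group for a cyclic amine; the steps of a 4.9-fold lower number from compound 1 to compound 2 (0.69 log units; beyond the scatter) and a 1.7-fold lower number from compound 1 to compound 3 (0.24 log units; within the scatter) show only that arylamino groups gave numbers lower than, or indistinguishable from, benzyl. Compound 4 is therefore expected to give a somewhat higher number, a step of a 2.1-fold higher number from compound 3 to compound 4 (0.33 log units; beyond the scatter). For compound 4 the estimated value in this assay is 600 nM, with a range from 150 nM to 2500 nM.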

Compound 4, half-maximal inhibitory concentration: 674 nM
Estimate against measurement, compound 4: 1.1-fold (0.05 log units) below; measured number inside the range.
By their numbers in this assay, from the lowest: compound 2; then compounds 3, 1 and 4 (each within the scatter of the next, the first and the last beyond it).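

In this assay, swapping an arylamino group for pyrrolidin-1-yl on this aromatic carbon gives a 2.4-fold higher number from compound 3 to compound 4 (0.38 log units; beyond the scatter) and a 6.8-fold higher number from compound 2 to compound 4 (0.83 log units; beyond the scatter) as the two steps, so both arylamino compounds differ from the cyclic amine beyond the scatter. The remaining step, a 1.4-fold higher number from compound 1 to compound 4 (0.14 log units; within the scatter) in size, stays within the scatter, so pyrrolidin-1-yl and benzyl cannot be told apart here. No measured evidence accounts for these steps. The swap removes both the aromatic ring and the amine hydrogen, and the compounds shown cannot separate the two changes. Cyclohexylamino, which keeps that hydrogen without an aromatic ring, remains an open comparison.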